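The compounds below may be only part of what the source reports. "The series", "measured", "known", "first", "only" and "open" are said of these compounds alone.

The study compares three compounds on one shared core in an assay on A549 cells for inhibition of transcription factor p65 (Homo sapiens), read by fluorescence, with a stated time of 2 h; a higher number here means a weaker inhibitor, a lower number a stronger inhibitor. Compound 1 `Nc1ccc(C(=O)/C=C/c2ccc(O)c(F)c2)cc1-c1ccc(F)cc1` reaches only the limit of the assay, giving > 50000 nM. Compound 2 `COc1ccc(/C=C/C(=O)c2ccc(N)c(-c3ccc(F)cc3)c2)cc1OC` likewise sits at a limit, with > 50000 nM, so its standing is known only as a limit and not as a number. Compound 3 `COc1cc(/C=C/C(=O)c2ccc(N)c(-c3ccc(F)cc3)c2)cc(OC)c1OC` gives 11600 nM. Among the measured compounds shown here, the single measured step is an at least 4.3-fold lower number from compound 2 to compound 3 (0.63 log units; beyond the scatter), by methoxy in place of hydrogen on an aromatic carbon, and the limit of > 50000 nM in this assay, at which 2 of the 3 values shown sit, makes its size a lower bound only. Compound 4 `COc1ccc(/C=C/C(=O)c2ccc(N)c(-c3ccc(F)cc3)c2)cc1` differs from compound 2 by hydrogen in place of methoxy on an aromatic carbon. For the measured compounds named here, this removes a methoxy rather than adding one, so the one step available runs the other way, and no improvement is expected. Compound 4 is expected at 60000 nM, between 20000 nM and 200000 nM, a step that the limit leaves unreadable from compound 2 to compound 4, most likely again reported only as a limit.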

Compound 4, half-maximal inhibitory concentration: > 50000 nM
Compound 4 ended at the assay's limit; the forecaster's own chance of this, stated with the estimate: 80%; the middle value lies beyond the limit too.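

No new step can be read from compound 1 or compound 2 to compound 4, because each of these results is only a limit: the limit of > 50000 nM in this assay, at which 3 of the 4 values shown sit. The compounds shown leave open how these three actually rank, and what the methoxy separating compound 2 from compound 4 changes.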